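The source may report more compounds than this note shows. Statements on the series, on what has been measured and on what is new or still open speak of the compounds shown alone.

Measured so far in an assay on microsomes from brain for inhibition of Fatty-acid amide hydrolase 1 (Rattus norvegicus), read by fluorescence and HPLC, with a stated time of 60 min; on this read-out lower numbers stand for stronger inhibition and higher numbers for weaker inhibition:
compound 1, `CCCCCCCCc1ccc(OCC(=O)Cn2nnnc2C)cc1`, gives 41 nM
compound 2, `CCCCCCCCc1ccc(OCC(=O)Cn2nnnc2SC)cc1`, gives 22 nM
compound 3, `CCCCCCCCc1ccc(OCC(=O)Cn2nnnc2-c2ccccc2)cc1`, gives 71 nM

Among these three, compound 3 has the highest number in this assay. The step of a 1.7-fold higher number from compound 1 to compound 3 (0.24 log units; within the scatter) stays within the scatter, while the step of a 3.2-fold higher number from compound 2 to compound 3 (0.51 log units; beyond the scatter) lies beyond it. Compound 4, `CCCCCCCCc1ccc(OCC(=O)Cn2nnnc2-c2ccc(Cl)cc2)cc1`, differs from compound 3 by chloro in place of hydrogen on an aromatic carbon. Going by the values given here, none of the measured steps touches the phenyl group itself; each of them swaps the whole group on the aromatic carbon of the shared core, and those swaps moved the numbers little (a 1.9-fold lower number from compound 1 to compound 2 (0.27 log units; within the scatter)) or modestly (a 3.2-fold higher number from compound 2 to compound 3 (0.51 log units; beyond the scatter)). With nothing in the data bearing directly on a chloro group at this place, no step beyond the scatter is expected in this assay. Compound 4 is therefore estimated at 60 nM, in the range 25 nM to 150 nM, which means an expected step of a 1.2-fold lower number from compound 3 to compound 4 (0.07 log units; within the scatter).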

Compound 4, half-maximal inhibitory concentration: 130 nM
For compound 4 the middle estimate is 2.2-fold (0.34 log units) below the measured one; measured number inside the range.
By their numbers in this assay, from the lowest: compounds 2, 1, 3 and 4 (each within the scatter of the next, the first and the last beyond it).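

Chloro in place of hydrogen, the only change shown on the phenyl group itself, gives a 1.8-fold higher number from compound 3 to compound 4 (0.26 log units; within the scatter) in this assay, so this place takes a chloro group without a clear shift. Replacing the methyl or methylsulfanyl group with 4-chlorophenyl gives larger steps, a 3.2-fold higher number from compound 1 to compound 4 (0.50 log units; beyond the scatter) and a 5.9-fold higher number from compound 2 to compound 4 (0.77 log units; beyond the scatter), and these are beyond the usual scatter. Nothing available explains these numbers. Still open, as far as these compounds go, is whether a different group at this place, such as methoxy, an amine or a carboxylic acid, would move the number beyond the scatter.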